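Cytotoxicity notes on the bromovinyl series, epimer step

The source may hold more compounds than are shown below. What is called first, only, known or untested is meant among the compounds shown, and "the series" means these compounds.

Compound 1 `O=c1[nH]c(=O)n([C@H]2CO[C@@H](CO)O2)cc1/C=C/Br` and compound 2 `O=c1[nH]c(=O)n([C@H]2CO[C@@H](CO)S2)cc1/C=C/Br` are both in hand. In a functional assay on Vero cells (Chlorocebus sabaeus) for cytotoxicity (a higher number here means that more compound is tolerated, a lower number that less compound is tolerated), compound 1 gives 100 ug/mL, and in this assay compound 2 gives 100 ug/mL, so compound 2 stands level with compound 1 within the scatter. Compound 3 `O=c1[nH]c(=O)n([C@@H]2CO[C@@H](CO)S2)cc1/C=C/Br` is still to be measured. Compound 3 differs from compound 2 as follows: the two compounds have the same atoms and bonds and differ only in configuration as drawn: 1 of 3 stereo elements differ; a stereocentre at a saturated ring carbon is drawn R in compound 2 and S in compound 3. Among the compounds with values here, no step between measured compounds is available to size this change, so no shift beyond the scatter is expected in either direction. Compound 3 is therefore estimated at 100 ug/mL, between 50 ug/mL and 200 ug/mL, which means an expected step of no change at the digits printed from compound 2 to compound 3 (within the scatter).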

Compound 3, half-maximal cytotoxic concentration: 30 ug/mL
Estimate against measurement, compound 3: 3.3-fold (0.52 log units) above; the measured number lies below the stated range.
By their numbers in this assay, from the lowest: compound 3; then compounds 1 and 2 (each within the scatter of the next).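

In this assay, the configuration at this saturated ring carbon matters, with a 3.3-fold lower number from compound 2 to compound 3 (0.52 log units; beyond the scatter), so the S form is less tolerated than the R form in this pair. Within the data shown here, this is the first sized step at this position, and it involves no change of atoms or bonds. The shift can therefore be assigned to configuration alone: the fact that compounds 2 and 3 differ only in the configuration as drawn

On these data alone, whether the same inversion on the core of compound 1 gives a comparable step remains open. So does whether the step persists with an amine in place of the bromine.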